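From thiophen-2-yl to 2-hydroxyphenyl on the sulfonyl sulfur

The compounds below may be only part of what the source reports. "The series", "measured", "known", "first", "only" and "open" are said of these compounds alone.

In an ADME assay on HEK293 cells (Homo sapiens) for cytotoxicity, read by resazurin assay, with a stated time of 48 h (on this read-out lower numbers stand for higher toxicity in this test and higher numbers for lower toxicity in this test), compound 1 `C=Cc1ccc(S(=O)(=O)Nc2ccc3oc(-c4ccccc4)nc3c2)cc1` gives 53000 nM and compound 3 `O=S(=O)(Nc1ccc2oc(-c3ccccc3)nc2c1)c1cccs1` gives 97000 nM, so these two cannot be told apart: the measured change is a 1.8-fold higher number from compound 1 to compound 3 (0.26 log units; within the scatter). Compound 2 `O=S(=O)(Nc1ccc2oc(-c3ccccc3)nc2c1)c1cccc(O)c1` reads > 100000 nM, which is a limit of the assay and not a number. Compound 4 `O=S(=O)(Nc1ccc2oc(-c3ccccc3)nc2c1)c1ccccc1O` differs from compound 3 in one place: 2-hydroxyphenyl in place of thiophen-2-yl on a sulfonyl sulfur. This is 2-hydroxyphenyl in place of thiophen-2-yl on a sulfonyl sulfur. The two other exchanges at this place are an at least 1.8-fold higher number from compound 1 to compound 2 (0.27 log units; that floor lies within the scatter) and an at least 1.0-fold lower number from compound 2 to compound 3 (0.01 log units; that floor lies within the scatter), and neither shows a change beyond the scatter. In this assay, the expected step is therefore none beyond the scatter: a 1.0-fold lower number from compound 3 to compound 4 (0.01 log units; within the scatter). The estimate for compound 4 is 95000 nM, with an expected range from 45000 nM to 200000 nM.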

Compound 4, half-maximal cytotoxic concentration: 33000 nM
Compound 4: middle estimate off by 2.9-fold (0.46 log units), on the high side; measured number outside the range, below it.
By their numbers in this assay, from the lowest: compounds 4, 1 and 3 (each within the scatter of the next, the first and the last beyond it). At a limit, above all of these: compound 2.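

On the sulfonyl sulfur, the choice of group can move the number beyond the scatter in this assay, where a lower number means higher toxicity: the result is a 2.9-fold lower number from compound 3 to compound 4 (0.47 log units; beyond the scatter), and also an at least 3.0-fold lower number from compound 2 to compound 4 (0.48 log units; beyond the scatter), so 2-hydroxyphenyl and 3-hydroxyphenyl do not read alike. Compound 2 stands at a limit and not at a number: the limit of > 100000 nM in this assay, at which 1 of the 4 values shown sits. The 2-hydroxyphenyl group stays within the scatter of 4-vinylphenyl, with a 1.6-fold lower number from compound 1 to compound 4 (0.21 log units; within the scatter).

Still open, on these data alone, is how a 4-hydroxyphenyl group or a phenyl ring carrying an amine or a carboxylic acid would read at this place. These values do not tell why the number falls.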